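Swapping Chloro for Nitro on Two Different Cores

A few compounds are considered here, and "the series" means these few. Any claim that something is new, unique, unknown or untested is made for them only; others in the source may bear on it.

Compound 1 `Clc1cccc(Nc2nc3ncccc3n2Cc2ccccc2)c1` and compound 2 `O=[N+]([O-])c1cccc(Nc2nc3ncccc3n2Cc2ccccc2)c1` share one core. In a functional assay on MCF7 cells (Homo sapiens) for antiproliferative activity, read by MTT assay, with a stated time of 72 h (a lower number here means a stronger inhibitor of growth, a higher number a weaker inhibitor of growth), compound 1 gives 43500 nM, and compound 2 gives 24200 nM. The change between them is nitro in place of chloro on an aromatic carbon, and it made a 1.8-fold lower number from compound 1 to compound 2 (0.25 log units; within the scatter). Compound 3 `Cn1nc(-c2ccnc(Nc3cccc(Cl)c3)n2)c2ccccc21` rests on a different core; how the two cores differ is not broken down here. In this assay compound 3 gives 5970 nM, the lowest of the three numbers. Compound 4 `Cn1nc(-c2ccnc(Nc3cccc([N+](=O)[O-])c3)n2)c2ccccc21` carries the same change on this second core: nitro in place of chloro on an aromatic carbon. Because the earlier step of a 1.8-fold lower number from compound 1 to compound 2 (0.25 log units; within the scatter) stayed within the scatter, a similarly small step is expected here, a 1.5-fold lower number from compound 3 to compound 4 (0.17 log units; within the scatter). Compound 4 is therefore expected to give about 4000 nM, most likely somewhere between 1500 nM and 12000 nM.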

Compound 4, concentration for 50% growth inhibition: 580 nM
Beside the measured number, compound 4's estimate is 6.9-fold (0.84 log units) above it; measured number outside the range, below it.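

The change from chloro to nitro did not carry over unchanged from one core to the other: on the second core it gave a 10-fold lower number from compound 3 to compound 4 (1.01 log units; beyond the scatter). Set beside the step on the first core in this assay, the two results clearly differ: the same change on two cores in this assay, a 1.8-fold lower number (0.25 log units; within the scatter) from compound 1 to compound 2 and a 10-fold lower number (1.01 log units; beyond the scatter) from compound 3 to compound 4, 5.7-fold (0.76 log units) apart, beyond the scatter of two such steps. This shows that the size of the step depends on the core in this pair of cores, but it does not show why, or which part of the cores is responsible.

The compounds shown carry only chloro or nitro at this place, on just two cores. On these data alone, whether an amine, a nitrile or a carboxylic acid there would also give a lower number on the second core remains open.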